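This account rests on a few compounds, and the source may have more. Where it says the series, first, only, none or still open, it means among the compounds named here.

The measured compounds, with their results in a functional assay on PC-3 cells (Homo sapiens) for antiproliferative activity, read by MTT assay, with a stated time of 72 h; a lower number here means a stronger inhibitor, a higher number a weaker inhibitor:
Compound 1, `O=C(COc1ccc(C(=O)/C=C/c2ccccc2Cl)cc1)N[C@H]1CCOC1=O`, compound 1 gives 4610 nM.
Compound 2, `CCOc1ccccc1OCCSC(=S)N[C@H]1CCOC1=O`, compound 2 gives 24100 nM.
Compound 3, `O=C(COc1ccc(C(=O)/C=C/c2ccccc2Br)cc1)N[C@H]1CCOC1=O`, compound 3 gives 3260 nM.

Compound 3 gives the lowest of the three numbers, but its gap to compound 1 lies within the scatter, so the two cannot be ranked against each other. Compound 2, built on a different core, gives a number beyond the scatter above that of compound 3 in this assay.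

Compound 4, `COc1ccccc1/C=C/C(=O)c1ccc(OCC(=O)N[C@H]2CCOC2=O)cc1`, has not yet been tested. It differs from compound 3 by methoxy in place of bromo on an aromatic carbon. Going by the values given here, only one measured step touches the same place: a 1.4-fold lower number from compound 1 to compound 3 (0.15 log units; within the scatter), which swaps one halogen for another and leaves the number essentially unchanged. Among the compounds with values here, no measured pair shows a halogen replaced by a methoxy group, so the direction of the coming step cannot be read from these data. Given a 1.4-fold lower number from compound 1 to compound 3 (0.15 log units; within the scatter), compound 4 is expected to land near compound 3, with a 1.2-fold higher number from compound 3 to compound 4 (0.09 log units; within the scatter) expected to stay within or close to the scatter. The estimate for compound 4 in this assay is 4000 nM, with a range from 1500 nM to 12000 nM.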

Compound 4, half-maximal inhibitory concentration: 7240 nM
Compound 4: middle estimate off by 1.8-fold (0.26 log units), on the low side; the range from low to high includes it.
By their numbers in this assay, from the lowest: compounds 3, 1 and 4 (each within the scatter of the next, the first and the last beyond it); then compound 2.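

In this assay, going by these compounds alone, exchanging the 2-bromophenyl for the 2-methoxyphenyl gives a 2.2-fold higher number from compound 3 to compound 4 (0.35 log units; beyond the scatter), a modest change, yet the only step at this place that lies beyond the scatter, so this position does not respond to every exchange in the same way. The same methoxy group measured against chloro gives a 1.6-fold higher number from compound 1 to compound 4 (0.20 log units; within the scatter), which means that methoxy separates from bromo but not from chloro, and the two halogens themselves could not be separated earlier, so the whole spread among these three groups remains small and any ranking rests on a single step. Nothing available explains why methoxy differs from bromo here, and no measured property of these groups bears on the result.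

The compounds shown leave open how this position responds to a group of a different kind, such as an amine, a hydroxyl or a carboxylic acid, or to a longer chain such as ethoxy in place of methoxy. They also leave open whether the ring needs any group at this place at all, since the plain phenyl, carrying only hydrogen there, does not appear among them.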